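The source may hold more compounds than are shown below. What is called first, only, known or untested is meant among the compounds shown, and "the series" means these compounds.

In a functional assay with Oryctolagus cuniculus as the target (on this read-out lower numbers stand for stronger inhibition and higher numbers for weaker inhibition), compound 1 `CC/N=C(/N)Nc1nc(-c2ccc(OC)cc2)c(-c2ccc(OC)cc2)s1` reports only a limit, > 100 nM. Compound 2 `COc1ccc(-c2nc(CNC(C)=O)sc2-c2ccc(OC)cc2)cc1` gives 15 nM. Compound 3 `CNC(=O)NCc1nc(-c2ccc(OC)cc2)c(-c2ccc(OC)cc2)s1` gives 22 nM, which places it level with compound 2 within the scatter. Both have numbers well clear of the limit of compound 1.

The next compound, compound 4 `COc1ccc(-c2nc(C(N)=O)sc2-c2ccc(OC)cc2)cc1`, carries carbamoyl in place of ((methylcarbamoyl)amino)methyl on an aromatic carbon. Going by the values given here, three measured steps bear on this change. Two start from the limit, an at least 6.6-fold lower number from compound 1 to compound 2 (0.82 log units; beyond the scatter) and an at least 4.5-fold lower number from compound 1 to compound 3 (0.65 log units; beyond the scatter), and they show that the group at this place can move the read-out beyond the scatter. The third, a 1.5-fold higher number from compound 2 to compound 3 (0.17 log units; within the scatter), swaps methyl for methylamino on a carbonyl carbon and stays within the scatter, so the far end of the chain in compound 3 can change with little effect on this assay. Among the compounds with values here, no measured step, however, cuts the chain back to carbamoyl, so this expectation is an extrapolation. A modest move towards a higher number, meaning weaker inhibition, seems most likely, and the result could also reach the limit. The expected change is a 2.0-fold higher number from compound 3 to compound 4 (0.31 log units; beyond the scatter). For compound 4 the estimated value is 45 nM, with an expected range from 12 nM to 150 nM.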

Compound 4, half-maximal inhibitory concentration: > 1000 nM
Compound 4: only a limit was reported (the forecaster's own chance of this, stated with the estimate: 25%); middle value at least 22-fold (1.34 log units) from the limit.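

Compound 4 stands at a limit and not at a number: the limit of > 1000 nM in this assay, at which 1 of the 4 values shown sits. In this assay, carbamoyl in place of ((methylcarbamoyl)amino)methyl gives an at least 45-fold higher number from compound 3 to compound 4 (1.65 log units; beyond the scatter), and carbamoyl in place of acetamidomethyl gives an at least 66-fold higher number from compound 2 to compound 4 (1.82 log units; beyond the scatter), both large steps at the same aromatic carbon, next to the ring nitrogen and next to the ring sulfur. The earlier compounds showed only that the far end of the chain could change within the scatter, as between compound 2 and compound 3, whereas these steps show that cutting the chain back to carbamoyl is not tolerated in the same way, so the inhibition seen with the two longer groups does not survive in the shortest group shown here.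

Compound 1 and compound 4 both carry limits, and the step between them cannot be read. The compounds shown leave open how much of the chain is needed, and whether a simple amine such as aminomethyl, a carboxylic acid or a longer chain at this place would stay with compound 2 and compound 3 or fall with compound 4.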